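This account rests on a few compounds, and the source may have more. Where it says the series, first, only, none or still open, it means among the compounds named here.

Values so far in a functional assay on PANC-1 cells (Homo sapiens) for inhibition, read by MTT assay, with a stated time of 24 h; on this read-out lower numbers stand for stronger inhibition and higher numbers for weaker inhibition:

- compound 1 `CC1(C)[C@H]2CC[C@]1(C)N(Cc1cn(-c3ccccc3F)nn1)C(=O)C2` gives 150 nM
- compound 2 `CC1(C)[C@H]2CC[C@]1(C)N(Cc1cn(-c3cccc(O)c3)nn1)C(=O)C2` gives 280 nM
- compound 3 `Cc1cccc(-n2cc(CN3C(=O)C[C@@H]4CC[C@@]3(C)C4(C)C)nn2)c1` is not yet measured

Going by the values given here, compound 2 is one of only two measured compounds, and its value lies within the scatter of the value for compound 1. Among the compounds with values here, the sole measured step (a 1.9-fold higher number from compound 1 to compound 2 (0.27 log units; within the scatter)) places 3-hydroxyphenyl where 2-fluorophenyl stood on an aromatic nitrogen, so no order can be drawn between the two.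

The next change puts methyl in place of hydroxy on an aromatic carbon, meta to a large group (methyl in place of hydroxy on an aromatic carbon). Within the data shown here, no measured step makes this exchange directly. The nearest evidence is the step already given (a 1.9-fold higher number from compound 1 to compound 2 (0.27 log units; within the scatter)), which also alters the group on the aromatic nitrogen and stays within the scatter. Among the measured compounds shown here, with only this guide, no change beyond the scatter is expected in this assay, and no direction is favoured with any confidence. The expected step (a 1.2-fold lower number from compound 2 to compound 3 (0.09 log units; within the scatter)) is estimated to remain within the scatter. For compound 3 the estimated value is 230 nM (expected range 90 nM to 600 nM).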

Compound 3, half-maximal inhibitory concentration: 240 nM
Beside the measured number, compound 3's estimate is 1.0-fold (0.02 log units) below it; measured number inside the range.
By their numbers in this assay, from the lowest: compounds 1, 3 and 2 (each within the scatter of the next).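

In this assay the exchange of hydroxy for methyl on the aromatic carbon gives a 1.2-fold lower number from compound 2 to compound 3 (0.07 log units; within the scatter) as its step, so at this position, meta to a large group, the hydrogen-bond donor and acceptor counted for hydroxy can leave without a shift beyond the scatter. The wider exchange on the aromatic nitrogen reads a 1.6-fold higher number from compound 1 to compound 3 (0.20 log units; within the scatter) as its step, which leaves 2-fluorophenyl, 3-hydroxyphenyl and 3-methylphenyl all within the scatter of one another and gives no order among compounds 1, 2 and 3 in this assay. No supporting measurement on any property of these groups bears on this result, and the numbers stand here without an explanation.

Still open, as far as these compounds go, is whether any group at this aromatic carbon moves the number beyond the scatter, for instance an amine, a carboxylic acid or a longer chain such as propyl in place of methyl. The compounds shown also leave open whether the placing of a group on the phenyl ring matters, since 2-fluorophenyl differs from 3-methylphenyl in both the group and its place.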